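The Same Acyl Exchange Repeated on a Second Core

The source may report more compounds than this note shows. Statements on the series, on what has been measured and on what is new or still open speak of the compounds shown alone.

Compound 1 `CCOC(=O)/C=C/[C@H](CC(C)C)NC(=O)[C@H](CC(C)C)NC(=O)[C@H](CC(C)C)NC(=O)C1=CCCNC1` and compound 2 `CCOC(=O)/C=C/[C@H](CC(C)C)NC(=O)[C@H](CC(C)C)NC(=O)[C@H](CC(C)C)NC(=O)c1cccc(O)c1C` share one core and differ by a group of 8 heavy atoms (7 carbon, 1 oxygen; one six-membered aromatic ring of carbon only) in place of a group of 6 heavy atoms (5 carbon, 1 nitrogen; one six-membered non-aromatic ring with 1 hetero atom), on a carbonyl carbon. In an ADME assay on a cell-free system (plasma, Homo sapiens) for metabolic stability (a lower number here means that the compound disappears faster, a higher number that the compound lasts longer), compound 1 gives a value that is only a limit of the assay, > 6 h. Compound 2 likewise reaches that limit, > 6 h. The step that the two limits leave unreadable from compound 1 to compound 2 can therefore not be sized. Compound 3 `CCOC(=O)/C=C/[C@H](CC(C)C)NC(=O)[C@H](CO)NC(=O)[C@@H](NC(=O)C1=CCCNC1)C(C)C` stands on another core; the difference between the two cores is not broken down here. In this assay compound 3 also gives a limit, > 6 h. Compound 4 `CCOC(=O)/C=C/[C@H](CC(C)C)NC(=O)[C@H](CO)NC(=O)[C@@H](NC(=O)c1cccc(O)c1C)C(C)C` carries the same change on this core, (a group of 8 heavy atoms (7 carbon, 1 oxygen; one six-membered aromatic ring of carbon only) in place of a group of 6 heavy atoms (5 carbon, 1 nitrogen; one six-membered non-aromatic ring with 1 hetero atom), on a carbonyl carbon), at a place described in identical words. Because (the limit of > 6 h in this assay, at which 3 of the 3 values shown sit), compound 4 is expected to remain at the limit as well, the estimated step that the limit leaves unreadable from compound 3 to compound 4 being essentially flat. Compound 4 is thus estimated at 8 h.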

Compound 4, half-life: > 6 h
Compound 4 was reported as a limit; the forecaster's own chance of this, stated with the estimate: 85%; the middle value does not contradict the limit.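

In this assay, within the data shown here, compound 3 and compound 4 both give only a limit, so no step between them can be read. The compounds shown leave open their actual half-lives, and whether the exchange changes them on either core.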